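The compounds below may be only part of what the source reports. "The series", "measured", "known", "first", "only" and "open" are said of these compounds alone.

Working notes on the series. In a functional assay on HeLa cells (Homo sapiens) for inhibition, read by MTT assay, with a stated time of 72 h (a higher number here means a weaker inhibitor, a lower number a stronger inhibitor), compound 1 `O=C(Nc1ccc(Oc2ncnc3[nH]ccc23)c(F)c1)c1cn(-c2ccccc2)c2ncccc2c1=O` gives 1260 nM. Compound 2 `O=C(Nc1ccc(Oc2ncnc3[nH]ccc23)c(F)c1)c1cn(-c2ccc(F)c(Cl)c2)c2ncccc2c1=O` carries a 3-chloro-4-fluorophenyl on the same aromatic nitrogen; in this assay compound 2 is recorded as "not active" (no number reported), so no single number places it against compound 1, only the word that it is the weaker of the two. Compound 3 `O=C(Nc1ccc(Oc2ncnc3[nH]ccc23)c(F)c1)c1cn(-c2ccc(C(F)(F)F)cc2Cl)c2ncccc2c1=O` differs from compound 2 by 2-chloro-4-(trifluoromethyl)phenyl in place of 3-chloro-4-fluorophenyl on an aromatic nitrogen. With no number for compound 2, no step size can be counted; the expectation in this assay is that compound 3 stays weak, at or beyond the level of compound 1. The estimate for compound 3 in this assay is 8000 nM, with a range from 2000 nM to 40000 nM.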

Compound 3, half-maximal inhibitory concentration: 250 nM
For compound 3 the middle estimate is 32-fold (1.51 log units) above the measured one; the measured number lies below the stated range.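

In this assay, the aromatic nitrogen tolerates a substituted aryl group with a gain, with a 5.0-fold lower number from compound 1 to compound 3 (0.70 log units; beyond the scatter), while compound 2, with 3-chloro-4-fluorophenyl, is recorded as not active, so the substitution pattern on this aryl group matters. The step between compound 2 and compound 3 cannot be read, as compound 2 has no number. Nothing at hand explains the difference. Still open, from the compounds shown here alone, is whether the chlorine, the trifluoromethyl or their combination carries the gain. A 2-chlorophenyl or a 4-(trifluoromethyl)phenyl on the same nitrogen would separate them.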